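The source may hold more compounds than are shown below. What is called first, only, known or untested is meant among the compounds shown, and "the series" means these compounds.

Four compounds share one core and differ only in what hangs on a six-membered aromatic ring of carbon only. Compound 1 `Brc1cccc(-c2nnc(Cn3nnc4ccccc43)o2)c1` carries a 3-bromophenyl, compound 2 `Brc1ccc(-c2nnc(Cn3nnc4ccccc43)o2)cc1` a 4-bromophenyl, compound 3 `COc1cccc(-c2nnc(Cn3nnc4ccccc43)o2)c1` a 3-methoxyphenyl, and compound 4 `COc1ccc(-c2nnc(Cn3nnc4ccccc43)o2)cc1` a 4-methoxyphenyl; compound 4 has not yet been measured. In a functional assay on HeLa cells (Homo sapiens) for antiproliferative activity, read by MTT assay, with a stated time of 24 h (on this read-out lower numbers stand for stronger inhibition and higher numbers for weaker inhibition), compound 1 gives 301000 nM, compound 2 gives 305000 nM, and compound 3 gives 243000 nM. All three numbers lie close together, and none of the steps between them stands out from the scatter.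

The cores of compound 1 and compound 2 hold the same atoms joined differently: 4-bromophenyl in place of 3-bromophenyl on an aromatic carbon. The step of a 1.0-fold higher number from compound 1 to compound 2 (0.01 log units; within the scatter) shows no real movement. From compound 1 to compound 3 the change is methoxy in place of bromo on an aromatic carbon, and the step of a 1.2-fold lower number from compound 1 to compound 3 (0.09 log units; within the scatter) is likewise small. The same kind of change, though not the same, carries compound 2 to compound 4: methoxy in place of bromo on an aromatic carbon. The surroundings differ in one respect: in compound 1 the group sits meta to a large group, whereas in compound 2 it sits para to a large group.

Because the step of a 1.2-fold lower number from compound 1 to compound 3 (0.09 log units; within the scatter) barely moved the number, a step of similar size, a 1.2-fold lower number from compound 2 to compound 4 (0.09 log units; within the scatter), is expected from compound 2 to compound 4. Compound 4 is therefore estimated to give about 250000 nM in this assay, expected to fall between 150000 nM and 420000 nM.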

Compound 4, half-maximal inhibitory concentration: 269000 nM
For compound 4 the middle estimate is 1.1-fold (0.03 log units) below the measured one; the range from low to high includes it.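

In this assay, methoxy in place of bromo, para to a large group, gives a 1.1-fold lower number from compound 2 to compound 4 (0.05 log units; within the scatter), a step that does not stand out from the scatter. Set beside the same change on the other core, where the group sits in a different place on the ring, the two steps agree, and in this small series the swap of bromo for methoxy reads the same on both cores: the same change on two cores in this assay, a 1.2-fold lower number (0.09 log units; within the scatter) from compound 1 to compound 3 and a 1.1-fold lower number (0.05 log units; within the scatter) from compound 2 to compound 4, 1.1-fold (0.04 log units) apart, within the scatter of two such steps. Going by these compounds alone, this agreement shows only that the change has no measurable effect on either core in this one assay; two steps that both lie within the scatter cannot show that a change with a clear effect would carry from one core to another, and they say nothing about other cells or other read-outs.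

The compounds shown leave open whether any other group on this ring, such as an amine, a carboxylic acid or a longer chain like butoxy, would give a number that stands apart from these four. Within the data shown here, with no step here beyond the scatter, a real test of carrying a change between these cores still needs a change that moves the number on at least one of them.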